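A few compounds are considered here, and "the series" means these few. Any claim that something is new, unique, unknown or untested is made for them only; others in the source may bear on it.

Of the compounds shown here, two of a shared core have so far been measured in an assay on isolated protein for inhibition of leukotriene B4 receptor 1 (Homo sapiens), tested at 10 uM; on this read-out lower numbers stand for less inhibition and higher numbers for more inhibition at the one concentration tested (going by the name of the read-out). Compound 1 `CC(=O)c1cc(C)c(OCCCCC#N)cc1O` gives 79% in this assay, and compound 2 `C=CCc1cc(C(C)=O)c(O)cc1OCCCCC#N` gives 92%. For the measured compounds named here, the single measured step between them is a number 13 percentage points higher from compound 1 to compound 2 (beyond the scatter), so compound 2 stands highest of the two numbers in this assay, with compound 1 as its only neighbour, beyond the scatter below it. Compound 3 `C=CCc1cc(C(C)=O)c(O)cc1OCCCCCCCC#N` has not yet been measured. It differs from compound 2 in one place: 3-cyanopropyl in place of cyano on a saturated chain carbon, four bonds along the chain from an oxygen on an aromatic ring. Going by the values given here, no measured step bears on this change, because the step from compound 1 to compound 2 concerns another place on the core and says nothing about exchanging cyano for 3-cyanopropyl. With compound 2 already giving 92% in this assay, there is little room for a higher number, and the data give no guide to the size of any lower one. Compound 3 is therefore expected to give about 86% in this assay, within 66% to 97%. The expected step is a number 6 percentage points lower from compound 2 to compound 3 (within the scatter), within the scatter.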

Compound 3, a percentage reported as inhibition, at one concentration (the size of the read-out at that concentration, not a potency): 88%
Compound 3: middle estimate off by 2 percentage points, on the low side; low and high end bracket the measured number.
By their numbers in this assay, from the lowest: compounds 1, 3 and 2 (each within the scatter of the next, the first and the last beyond it).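

In this assay, the exchange of cyano for 3-cyanopropyl on a saturated chain carbon, four bonds along the chain from an oxygen on an aromatic ring, gives a number 4 percentage points lower from compound 2 to compound 3 (within the scatter). For the compounds shown here, this is the first reading at this place, since the earlier step concerned another part of the shared core, and it shows that the longer chain, still ending in a nitrile, leaves the number within the scatter of that of the shorter one. Nothing at hand explains this outcome at the level of the protein or of the groups involved.

Going by these compounds, what stays open is how far this holds: a shorter chain, a chain longer still, or another end group in place of the nitrile, such as a carboxylic acid, an amine or an amide, could each give a different number at this place. The read-out also reports inhibition at one concentration and not a potency, so whether the chain length matters at lower concentrations, where compound 2 and compound 3 might separate, cannot be told from these numbers.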